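This account rests on a few compounds, and the source may have more. Where it says the series, first, only, none or still open, it means among the compounds named here.

Compound 1 `Cc1ccc(-c2nc3ccccc3o2)cc1NC(=O)c1cc([N+](=O)[O-])ccc1Cl` has been run in an ADME assay on HEK293 cells (Homo sapiens) for cytotoxicity, with a stated time of 72 h; on this read-out higher numbers stand for an effect only at larger amounts of compound and lower numbers for an effect already at smaller amounts. Here compound 1 gives > 14000 nM, which is a limit of the assay and not a number. Compound 2 `O=C(Nc1ccc(O)c(-c2nc3ccccc3s2)c1)c1cc([N+](=O)[O-])ccc1Cl` belongs to the same set. In this assay compound 2 gives > 25000 nM, again a limit of the assay rather than a number. Going by the values given here, compound 1 thus stands at a limit, and the one further value shown is also a limit of > 14000 nM in this assay, at which 1 of the 2 values shown sits (the limit of > 25000 nM in this assay, at which 1 of the 2 values shown sits). Among the compounds with values here, no measured step between compounds that differ in one place is available, so the data do not yet size any change in this read-out.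

Compound 3 `O=C(Nc1cc(-c2nc3ccccc3o2)ccc1F)c1cc([N+](=O)[O-])ccc1Cl` has not been measured. It differs from compound 1 by fluoro in place of methyl on an aromatic carbon. The shared core and the amide part are kept. With both measured values sitting at limits, no direction can be read from the numbers. The step that the limit leaves unreadable from compound 1 to compound 3 is estimated as none beyond the scatter. Compound 3 is expected to give about 20000 nM in this assay, with a range from 8000 nM to 60000 nM, and a limit rather than a number is thought likely.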

Compound 3, half-maximal effective concentration: > 25000 nM
Compound 3: no number, only a limit (the forecaster's own chance of this, stated with the estimate: 80%); middle value at least 1.2-fold (0.09 log units) from the limit.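

In this assay compound 3 gives > 25000 nM, a limit of the assay and not a number. Going by these compounds alone, compound 1 also stands at a limit, and no step from compound 1 to compound 3 can be read. Still open is whether fluoro in place of methyl on an aromatic carbon changes this read-out at all, and where any compound shown would reach its half-maximal effect.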